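Swapping an Amide on a Fused Core: Expected Clearance

The source may hold more compounds than are shown below. What is called first, only, known or untested is meant among the compounds shown, and "the series" means these compounds.

Three compounds sharing the same amine side chain were measured in an ADME assay on microsomes from liver (Homo sapiens) for metabolic stability, read by LC-MS, using NADPH, with stated times of 5 min and 30 min, tested at 1 uM; on this read-out higher numbers stand for fast clearance and lower numbers for slow clearance. Compound 1 `CN(c1ccn(C)n1)c1cnc(NCc2c(F)ccc3c2CCO3)c2cn[nH]c(=O)c12` gives 62 mL.min-1.g-1. Compound 3 `Cc1nc(C(=O)N(C)C)ccc1-c1cnc(NCc2c(F)ccc3c2CCO3)c2cn[nH]c(=O)c12` gives 19 mL.min-1.g-1. Compound 2 `O=C(Nc1ccccc1)c1cnc(NCc2c(F)ccc3c2CCO3)n2cnnc12` gives 14 mL.min-1.g-1, the lowest of the three numbers, though its gap to compound 3 lies within the usual scatter, while its gap to compound 1 lies beyond it. Compound 4 `CN(C(=O)c1ccccc1)c1cnc(NCc2c(F)ccc3c2CCO3)n2cnnc12` has not yet been measured. It differs from compound 2 in one place: benzoyl(methyl)amino in place of phenylcarbamoyl on an aromatic carbon. Among the compounds with values here, no measured pair shows this exact change, so its effect is unknown. The step of a 1.8-fold higher number from compound 2 to compound 4 (0.25 log units; within the scatter) is expected to be a modest rise, near the edge of the scatter. Compound 4 is therefore estimated at 25 mL.min-1.g-1, with a range from 10 mL.min-1.g-1 to 60 mL.min-1.g-1.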

Compound 4, intrinsic clearance in microsomes: > 300 mL.min-1.g-1
Compound 4 ended at the assay's limit (the forecaster's own chance of this, stated with the estimate: 5%); middle value at least 12-fold (1.07 log units) away from the limit.
By their numbers in this assay, from the lowest: compounds 2 and 3 (each within the scatter of the next); then compound 1. At a limit, above all of these: compound 4.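

At this position on the shared core, two groups that both carry a carbon-only aromatic ring and a carbonyl are far from interchangeable: in this assay, benzoyl(methyl)amino in place of phenylcarbamoyl gives an at least 21-fold higher number from compound 2 to compound 4 (1.33 log units; beyond the scatter). The value of compound 4 is a limit of the assay, not a number: the limit of > 300 mL.min-1.g-1 in this assay, at which 1 of the 4 values shown sits.

The compounds shown leave open whether the reversed amide or the added methyl drives this step. Benzoylamino, without the methyl, or phenylcarbamoyl with a methyl on its nitrogen, would separate the two.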